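Microsomal half-life notes: cyclopropyl to pentan-3-yl

The source may hold more compounds than are shown below. What is called first, only, known or untested is meant among the compounds shown, and "the series" means these compounds.

The series shares a core carrying a fluoronaphthyl group, shown in compound 1 `C/C(=C1/OC(=O)NC1=O)C(c1ccc(-c2ccc3cccc(F)c3c2)[nH]c1=O)C(C)C`, compound 2 `CC(C)C(/C=C1\OC(=O)NC1=O)c1cc(Cl)c(-c2ccc3cccc(F)c3c2)[nH]c1=O` and compound 3 `O=C1NC(=O)/C(=C/C(c2ccc(-c3ccc4cccc(F)c4c3)[nH]c2=O)C2CC2)O1`. In an ADME assay on microsomes from liver (Homo sapiens) for metabolic stability (a higher number here means that the compound lasts longer, a lower number that the compound disappears faster), compound 1 gives > 3 h, which is a limit of the assay and not a number. Compound 2 also gives > 3 h in this assay, again a limit. Within the data shown here, compound 3 is the only one with a measured number, giving 1.98 h in this assay; it therefore stands below (the limit of > 3 h in this assay, at which 2 of the 3 values shown sit). Among the measured compounds shown here, compound 3 differs from compound 1 and from compound 2 in more than one place, so only the bare values can be set side by side, and no single step between them can be read.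

The next compound, compound 4 `CCC(CC)C(/C=C1\OC(=O)NC1=O)c1ccc(-c2ccc3cccc(F)c3c2)[nH]c1=O`, is compound 3 with one change: pentan-3-yl in place of cyclopropyl on a saturated chain carbon bound to an aromatic carbon and a double-bonded chain carbon. For the measured compounds named here, no measured step of this kind exists, so the expectation rests on the values alone. Because compound 1 sits at > 3 h and compound 2 at > 3 h while compound 3 sits at 1.98 h, no step beyond the usual scatter is expected in this assay, with an estimated step of a 1.3-fold higher number from compound 3 to compound 4 (0.10 log units; within the scatter). For compound 4 the estimated half-life in this assay is 2.5 h, expected within 1.2 h to 5 h.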

Compound 4, half-life: > 3 h
Compound 4: a limit, no number; the forecaster's own chance of this, stated with the estimate: 35%; at least 1.2-fold (0.07 log units) between middle value and limit.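

Pentan-3-yl in place of cyclopropyl on a saturated chain carbon bound to an aromatic carbon and a double-bonded chain carbon gives the first single-change step that can be read in this assay: an at least 1.5-fold higher number from compound 3 to compound 4 (0.18 log units; that floor lies within the scatter). As far as these compounds go, compound 4 gives > 3 h, a limit of the assay and not a number, and the step read from it is a floor whose true size stays unknown. Among these compounds, the ring at this position can thus give way to an open chain of pentan-3-yl with no measured loss of half-life, and compound 3 remains the only compound with a number: the limit of > 3 h in this assay, at which 3 of the 4 values shown sit.

The compounds shown leave open how far past the limit compound 4 lies, and whether the size of the group or the loss of the ring matters more for the half-life at this position. They also leave open how an amine or a carboxylic acid on this saturated chain carbon would read in this assay.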